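From 3-chlorophenyl to 4-chlorophenyl on an amide nitrogen

A few compounds are considered here, and "the series" means these few. Any claim that something is new, unique, unknown or untested is made for them only; others in the source may bear on it.

Compound 1 (`O=C(O)CCCCC(CCSC(=O)c1ccccc1)SC(=O)c1ccccc1`) - 81%
Compound 2 (`O=C(CCCCC(CCSC(=O)c1ccccc1)SC(=O)c1ccccc1)Nc1cccc(Cl)c1`) - "not active" (no number reported)

In a functional assay on Bel-7402 cells (Homo sapiens) for inhibition, read by MTT assay, with a stated time of 24 h, tested at 100 ug/mL (a higher number here means more inhibition of growth at the concentration tested, a lower number less inhibition of growth), compound 1 gives 81% as its reading. Compound 2 has no single number on this scale, because it is recorded only as "not active" (no number reported) in the same test. Its place is therefore known in words, not as a percentage, and no size can be put on the gap between the two.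

Compound 3 (`O=C(CCCCC(CCSC(=O)c1ccccc1)SC(=O)c1ccccc1)Nc1ccc(Cl)cc1`) has not yet been measured. The structural change is confined to one place (4-chlorophenyl in place of 3-chlorophenyl on an amide-type nitrogen): 4-chlorophenyl in place of 3-chlorophenyl on an amide-type nitrogen, with the same atoms joined differently.

Among the compounds with values here, no measured step exists to guide the estimate, so the expectation rests on compound 2, recorded as "not active" (no number reported) in this assay here. The expected step is small and upward, most likely none beyond the scatter, and another report with no number would be no surprise. For compound 3 the estimated value is 20% (expected range 0% to 50%).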

Compound 3, percent growth inhibition at one concentration: "not active" (no number reported)
For compound 3 the study gives words and no number, and the estimate cannot be compared.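

Within the data shown here, compound 2 and compound 3 are both recorded only in words in this assay, so no step with a size can be read between them. No other measurement here bears on this result. The compounds shown leave open whether 3-chlorophenyl and 4-chlorophenyl on the amide nitrogen differ at all in growth inhibition.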